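Changing one ether chain on compound 2

The compounds below may be only part of what the source reports. "The series", "measured", "known", "first", "only" and "open" are said of these compounds alone.

Compound 1 `COc1ccc(/C(=N/O)c2cccc3ccccc23)c(OC)c1OC` gives 13100 nM
Compound 2 `COc1ccc(C(c2ccc(OC(C)CN(C)C)cc2)c2cccc3ccccc23)c(OC)c1OC` gives 11400 nM
Compound 3 `CCOC(=O)CO/N=C(/c1ccc(OC)c(OC)c1OC)c1cccc2ccccc12` gives 6720 nM

All three values come from a functional assay on A549 cells (Homo sapiens) for inhibition, read by sulforhodamine B assay, with a stated time of 48 h (on this read-out higher numbers stand for weaker inhibition and lower numbers for stronger inhibition), and lie within the usual scatter of one another. Compound 2 at 11400 nM therefore stands in the same band as compound 1 and compound 3, with no real gap to either.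

Compound 4 `COc1ccc(C(c2ccc(OCCO)cc2)c2cccc3ccccc23)c(OC)c1OC` has not been measured yet. It keeps the shared core of compound 2 and differs in one chain. The change is 2-hydroxyethyl in place of 1-((dimethylamino)methyl)ethyl on an oxygen on an aromatic ring and it sits on an oxygen on an aromatic ring.

Among the compounds with values here, no measured pair makes this exact swap. Within the data shown here, the only measured step is a 1.9-fold lower number from compound 1 to compound 3 (0.29 log units; within the scatter) and it concerns a different change, (ethoxycarbonyl)methyl in place of hydrogen on an oxygen. That step stays within the scatter, but it is a single pair and only loosely related.

Starting from compound 2, no step beyond the scatter is expected in this assay and the data give no direction. The expected change is a 1.0-fold lower number from compound 2 to compound 4 (0.02 log units; within the scatter) and this estimated step is small. Among the measured compounds shown here, no measured step tests this chain directly, so the range is kept wide. Compound 4 is estimated at 11000 nM with an expected range from 5000 nM to 25000 nM for a single measurement.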

Compound 4, half-maximal inhibitory concentration: > 20000 nM
Compound 4: no number, only a limit; the forecaster's own chance of this, stated with the estimate: 10%; middle value at least 1.8-fold (0.25 log units) away from the limit.
By their numbers in this assay, from the lowest: compounds 3, 2 and 1 (each within the scatter of the next). At a limit, above all of these: compound 4.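

In this assay, compound 4 gives > 20000 nM, which is a limit of the assay and not a number. Within the data shown here, the step therefore has only a floor, an at least 1.7-fold higher number from compound 2 to compound 4 (0.24 log units; that floor lies within the scatter), so the true gap may be small or much larger, and the data cannot say which: the limit of > 20000 nM in this assay, at which 1 of the 4 values shown sits. Even so, this is the first look at the ether chain on this oxygen on an aromatic ring, since the one earlier step concerned a different change on a different core, and it shows that a chain without the dimethylamino nitrogen does not give a number inside the measured range of this assay.

The swap changes two things at once: the nitrogen leaves, and the chain goes from 1-((dimethylamino)methyl)ethyl to the smaller 2-hydroxyethyl, so the compounds shown cannot separate the loss of the amine from the change in chain size. A 2-(dimethylamino)ethyl chain would keep the amine on a shorter chain, and a longer chain ending in a hydroxyl group would keep the alcohol, so each would test one of these two changes alone.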